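Hydrazone aryl swap: chlorophenyl to hydroxynaphthyl

The compounds below may be only part of what the source reports. "The series", "measured", "known", "first", "only" and "open" are said of these compounds alone.

Working notes on the hydrazone series. The compounds share one core and differ only in the aryl group on the carbon with a double bond to nitrogen. Compound 2 `CN(C)CCn1cnnc1-c1cc(Oc2ccc(NC(=O)N/N=C/c3ccc(Cl)cc3)cc2F)ccn1` is the anchor: in a functional assay on A549 cells (Homo sapiens) for cytotoxicity, read by MTT assay, with a stated time of 72 h (a higher number here means a weaker inhibitor, a lower number a stronger inhibitor), compound 2 gives 780 nM, the lowest of the two numbers recorded, with compound 3 `CN(C)CCn1cnnc1-c1cc(Oc2ccc(NC(=O)N/N=C/c3cc(C(C)(C)C)cc(C(C)(C)C)c3O)cc2F)ccn1` beside it at 980 nM, a gap within the scatter, so no order between the two is claimed. Compound 1 `CN(C)CCn1cnnc1-c1cc(Oc2ccc(NC(=O)N/N=C/c3cccc(O)c3)cc2F)ccn1` reaches only a limit of the assay, > 100000 nM (the limit of > 100000 nM in this assay, at which 1 of the 3 values shown sits).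

The compound in question is compound 4 `CN(C)CCn1cnnc1-c1cc(Oc2ccc(NC(=O)N/N=C/c3c(O)ccc4ccccc34)cc2F)ccn1`. Its change from compound 2 is 2-hydroxynaphthalen-1-yl in place of 4-chlorophenyl on a carbon with a double bond to nitrogen.

Among the compounds with values here, only one measured step bears on it: an at least 120-fold lower number from compound 1 to compound 2 (2.10 log units; beyond the scatter), where a hydroxyphenyl group in place of the chlorophenyl lost activity beyond the limit. Against that, compound 3 also carries a hydroxyl on its aryl group and sits within the scatter of compound 2. A hydroxyl therefore need not be harmful, and compound 4 is expected to stay within the active pair rather than follow compound 1. The step of a 1.9-fold higher number from compound 2 to compound 4 (0.28 log units; within the scatter) is expected to be modest, a somewhat higher number, close to the scatter. Compound 4 is estimated at 1500 nM, with a range from 400 nM to 10000 nM.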

Compound 4, half-maximal inhibitory concentration: 880 nM
Beside the measured number, compound 4's estimate is 1.7-fold (0.23 log units) above it, within the range that was stated.
By their numbers in this assay, from the lowest: compounds 2, 4 and 3 (each within the scatter of the next). At a limit, above all of these: compound 1.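

In this assay, the step of a 1.1-fold higher number from compound 2 to compound 4 (0.05 log units; within the scatter) shows that the carbon with a double bond to nitrogen can carry 2-hydroxynaphthalen-1-yl in place of 4-chlorophenyl, a group with a second six-membered aromatic ring and a hydrogen-bond donor, with no change beyond the scatter. Within the data shown here, the step of an at least 110-fold lower number from compound 1 to compound 4 (2.05 log units; beyond the scatter) adds a second hydroxyl-bearing aryl group to the active set alongside compound 3, so a hydroxyl on the aryl group does not by itself go with the loss seen for compound 1, which remains the one compound against this reading. Compound 1 stands at a limit of the assay, so this step gives only a bound and not a size: the limit of > 100000 nM in this assay, at which 1 of the 4 values shown sits.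

On these data alone, what the hydroxyl contributes in compound 4 apart from the second ring stays open, and a plain naphthalen-1-yl group would separate the two. As far as these compounds go, whether the carbon with a double bond to nitrogen also keeps its activity with an aryl group carrying an amine or a carboxylic acid is equally open.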